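Ester alkyl variation: cyclopentyl in place of ethyl

This account rests on a few compounds, and the source may have more. Where it says the series, first, only, none or still open, it means among the compounds named here.

Measured so far in a functional assay (cardiac atrium) for agonist activity, with Cavia porcellus as the target; on this read-out higher numbers stand for an effect only at larger amounts of compound and lower numbers for an effect already at smaller amounts:
compound 1 `CCO/C(O)=C1\C(C)=NC(C)=C([N+](=O)[O-])C1c1ccncc1` — 6460 nM
compound 2 `CO/C(O)=C1\C(C)=NC(C)=C([N+](=O)[O-])C1c1ccncc1` — 48500 nM
compound 3 `CC1=NC(C)=C([N+](=O)[O-])C(c2cccnc2)/C1=C(\O)OC1CCCCC1` — 2760 nM

Compound 1 stands second highest of the three numbers; compound 3 is nearest to it and compound 2 furthest. Compound 4 `CC1=NC(C)=C([N+](=O)[O-])C(c2ccncc2)/C1=C(\O)OC1CCCC1` is not yet measured and differs from compound 1 in one place: cyclopentyl in place of ethyl on an oxygen on an unsaturated carbon. Among the compounds with values here, the only measured step touching the same oxygen is a 7.5-fold higher number from compound 1 to compound 2 (0.88 log units; beyond the scatter), where the group on that oxygen shrinks and the number rises. Compound 3, which carries a cyclohexyl on the same oxygen together with a different pyridyl, sits below compound 1. A larger group on that oxygen is therefore expected to lower the number in this assay, and the step from compound 1 to compound 4 is estimated as a 2.3-fold lower number from compound 1 to compound 4 (0.36 log units; beyond the scatter). Compound 4 is estimated at 2800 nM, with a range from 1100 nM to 7000 nM.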

Compound 4, half-maximal effective concentration: 4250 nM
Beside the measured number, compound 4's estimate is 1.5-fold (0.18 log units) below it; the range from low to high includes it.
By their numbers in this assay, from the lowest: compounds 3, 4 and 1 (each within the scatter of the next, the first and the last beyond it); then compound 2.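

In this assay cyclopentyl on this oxygen gives a 1.5-fold lower number from compound 1 to compound 4 (0.18 log units; within the scatter), so the read-out does not separate cyclopentyl from ethyl despite the added ring and carbons. Against methyl the same group gives an 11-fold lower number from compound 2 to compound 4 (1.06 log units; beyond the scatter), which places the one clear change in this pair of steps at methyl, while ethyl and cyclopentyl stay together. No measured evidence bears on the reason for this. Open, on these data alone, is whether a longer chain such as n-butyl, or a chain ending in an amine, on the same oxygen would fall with ethyl and cyclopentyl or with methyl. Also open, as far as these compounds go, is how cyclohexyl compares on the same pyridyl as compound 4.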